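From Compound 2 to Compound 3: One Added Methyl

This account rests on a few compounds, and the source may have more. Where it says the series, first, only, none or still open, it means among the compounds named here.

In a functional assay on Bel-7402 cells (Homo sapiens) for inhibition, read by sulforhodamine B assay, with a stated time of 72 h (on this read-out higher numbers stand for weaker inhibition and lower numbers for stronger inhibition), compound 1 (`C[C@H](Nc1ncnc2[nH]cnc12)c1nn(-c2cccnc2)c2cc(Cl)ccc12`) gives > 40000 nM, which is a limit of the assay and not a number. Compound 2 (`C[C@H](Nc1ncnc2[nH]cnc12)c1nn(-c2cccnc2)c2cc(F)ccc12`) gives > 40000 nM, again a limit and not a number. Compound 2 therefore stands at the limit of > 40000 nM in this assay, at which 2 of the 2 values shown sit.

Compound 3 (`CC[C@H](Nc1ncnc2[nH]cnc12)c1nn(-c2cccnc2)c2cc(F)ccc12`) departs from compound 2 by one change: methyl in place of hydrogen on a saturated chain carbon, two bonds along the chain from an aromatic carbon and a nitrogen on an aromatic ring. In words, this is methyl in place of hydrogen on a saturated chain carbon, two bonds along the chain from an aromatic carbon and a nitrogen on an aromatic ring, so that methyl becomes ethyl.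

Among the measured compounds shown here, the only measured step is a step that the two limits leave unreadable from compound 1 to compound 2, with fluoro in place of chloro on an aromatic carbon. It is a different change and offers no size to carry over. In this assay, no step beyond the scatter is expected and no direction can be given, as compound 2 offers only its limit of > 40000 nM. The expected step reads a number no higher from compound 2 to compound 3 (the limit leaves the size open). For compound 3 the estimated value is 40000 nM, with an expected range from 20000 nM to 80000 nM.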

Compound 3, half-maximal inhibitory concentration: 29000 nM
For compound 3 the middle estimate is 1.4-fold (0.14 log units) above the measured one; the range from low to high includes it.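

In this assay, the change of methyl to ethyl gives an at least 1.3-fold lower number from compound 2 to compound 3 (0.13 log units; that floor lies within the scatter). This is the first change in the series to yield a readable number, as compound 3 gives 29000 nM, though the compound remains far from strongly inhibiting by the numbers shown. Compound 2 remains a limit and not a number, so the printed step is only a floor, and the true size of the step, which may lie within the scatter or well beyond it, stays unknown: the limit of > 40000 nM in this assay, at which 2 of the 3 values shown sit.

The compounds shown leave open whether a longer chain such as propyl, or an amine on this same carbon, would carry the number further in either direction. They also leave open whether ethyl would act in the same way with chloro in place of fluoro on the aromatic carbon, since the step between the two halogens cannot be read from its two limits.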